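The source may hold more compounds than are shown below. What is called first, only, known or untested is meant among the compounds shown, and "the series" means these compounds.

Measured so far:
compound 1 `Cc1ccccc1N(C)C(=O)c1ccc(-c2ccc(OS(N)(=O)=O)cc2)o1` 28 nM
compound 2 `Cc1ccccc1N(C)C(=O)c1ccc(-c2ccc(OS(N)(=O)=O)cc2Cl)o1` 27 nM

Compound 2 holds the lowest of the two numbers in an assay on T47D cells for inhibition of Steryl-sulfatase (Homo sapiens), read by HPLC, with a stated time of 24 h (on this read-out lower numbers stand for stronger inhibition and higher numbers for weaker inhibition), with compound 1 giving 28 nM; the step of a 1.0-fold lower number from compound 1 to compound 2 (0.02 log units; within the scatter) is within the scatter. Compound 3 `Cc1ccccc1N(C)C(=O)c1ccc(-c2ccc(OS(N)(=O)=O)cc2F)o1` carries fluoro in place of chloro on an aromatic carbon, at the place described: ortho to a large group, meta to a sulfamoyloxy group. Going by the values given here, the one measured step bearing on this position, a 1.0-fold lower number from compound 1 to compound 2 (0.02 log units; within the scatter), showed that exchanging hydrogen for chloro there left this assay unchanged. Fluoro is expected to behave likewise, so no step beyond the scatter is expected, a 1.0-fold higher number from compound 2 to compound 3 (0.02 log units; within the scatter). Compound 3 is estimated at 28 nM, range 14 nM to 56 nM.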

Compound 3, half-maximal inhibitory concentration: 12 nM
Compound 3: middle estimate off by 2.3-fold (0.37 log units), on the high side, outside the stated range (below it).
By their numbers in this assay, from the lowest: compound 3; then compounds 2 and 1 (each within the scatter of the next).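

In this assay, this position proves sensitive to the choice of substituent: fluoro gives a 2.3-fold lower number from compound 1 to compound 3 (0.37 log units; beyond the scatter), and exchanging chloro for fluoro gives a 2.3-fold lower number from compound 2 to compound 3 (0.35 log units; beyond the scatter), whereas the earlier exchange of hydrogen for chloro stayed within the scatter. The outcome therefore depends on which halogen is present, not simply on whether the aromatic carbon carries a halogen. Nothing available explains the difference between fluoro and chloro here.

On these data alone, whether a methyl, a methoxy or an amine at this place would track with fluoro or with chloro remains open. Also open, as far as these compounds go, is whether a second fluoro on the same ring would add to this step.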